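Anilino-substituted tricyclic core: ethyl to methyl at the aniline

The compounds below may be only part of what the source reports. "The series", "measured", "known", "first", "only" and "open" are said of these compounds alone.

Measured so far:
compound 1, `Cc1ccc(NC2=CC(=O)c3c(nc4n3[C@H]3OC[C@@H](O)[C@H]3OC4)C2=O)cc1C` — 1050 nM
compound 2, `CCc1ccc(NC2=CC(=O)c3nc4n(c3C2=O)[C@H]2OC[C@@H](O)[C@H]2OC4)cc1` — 1290 nM

In a functional assay on MGC-803 cells (Homo sapiens) for inhibition, read by sulforhodamine B assay (on this read-out higher numbers stand for weaker inhibition and lower numbers for stronger inhibition), compound 1 gives 1050 nM and compound 2 gives 1290 nM. Compound 2 has the highest of the two numbers, but its gap to compound 1 lies within the scatter, so the two are not separated. Both share the same core and differ only in the substitution of the anilino ring, and neither is yet linked to another compound by a single-site step.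

Compound 3, `Cc1ccc(NC2=CC(=O)c3nc4n(c3C2=O)[C@H]2OC[C@@H](O)[C@H]2OC4)cc1`, follows from compound 2 by a single change: hydrogen in place of methyl on a saturated chain carbon bound to an aromatic carbon. Going by the values given here, with no comparable step measured, there is nothing in the numbers to anchor a direction, and both measured compounds sit close together despite differing aryl substitution. The step from compound 2 to compound 3 is therefore expected to be small, a 1.1-fold higher number from compound 2 to compound 3 (0.04 log units; within the scatter), with no movement beyond the scatter. In this assay compound 3 is estimated at 1400 nM, with a range from 700 nM to 2800 nM.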

Compound 3, half-maximal inhibitory concentration: 1420 nM
Estimate against measurement, compound 3: 1.0-fold (0.01 log units) below; the range from low to high includes it.
By their numbers in this assay, from the lowest: compounds 1, 2 and 3 (each within the scatter of the next).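

In this assay, the change from 4-ethylphenyl to 4-methylphenyl gives the series its first single-site step, a 1.1-fold higher number from compound 2 to compound 3 (0.04 log units; within the scatter), and that step does not separate the two compounds. Removing the methyl on the saturated chain carbon bound to an aromatic carbon therefore leaves the read-out unresolved from that of the ethyl compound, a result that two compounds differing in more than this one group could not show. No other measurement bears on this result.

Going by these compounds, whether a longer chain such as butyl at this position would move the number beyond the scatter remains open. The same holds for an amine or a carboxylic acid in place of the alkyl group on the aniline ring.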